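Chloro for Methyl on a Spiro-Oxindole Chromone Scaffold

The source may hold more compounds than are shown below. What is called first, only, known or untested is meant among the compounds shown, and "the series" means these compounds.

Measured compounds:
compound 1, `Cc1ccc2c(c1)C1(C(=O)N2C)C(C#N)=C(N)Oc2cc3oc(-c4ccccc4)cc(=O)c3c(O)c21`, 10200 nM
compound 2, `CN1C(=O)C2(C(C#N)=C(N)Oc3cc4oc(-c5ccccc5)cc(=O)c4c(O)c32)c2cc(Cl)ccc21`, 11200 nM
compound 3, `Cc1cccc2c1N(Cc1ccccc1)C(=O)C21C(C#N)=C(N)Oc2cc3oc(-c4ccccc4)cc(=O)c3c(O)c21`, > 50000 nM

The three compounds were tested in a functional assay on NCI-H1299 cells (Homo sapiens) for antiproliferative activity, read by MTT assay, with a stated time of 48 h; a higher number here means a weaker inhibitor, a lower number a stronger inhibitor. Compound 1 gives 10200 nM and compound 2 gives 11200 nM. The step between them is a 1.1-fold higher number from compound 1 to compound 2 (0.04 log units; within the scatter), and the change that produced it is chloro in place of methyl on an aromatic carbon. For compound 3 the result is only a limit, > 50000 nM, and the shape of this limit is the limit of > 50000 nM in this assay, at which 1 of the 3 values shown sits. The difference between the core of compound 1 and the core of compound 3 is not broken down here.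

Compound 4, `N#CC1=C(N)Oc2cc3oc(-c4ccccc4)cc(=O)c3c(O)c2C12C(=O)N(Cc1ccccc1)c1c(Cl)cccc12`, has not yet been measured in this assay. It differs from compound 3 by chloro in place of methyl on an aromatic carbon. Among the compounds with values here, this is the same kind of change as the one from compound 1 to compound 2, although the surroundings of the place differ: in the earlier pair the position is meta to a fused ring and para to a fused ring, whereas in the new pair it is ortho to a fused ring and meta to a fused ring.

Because the earlier step was a 1.1-fold higher number from compound 1 to compound 2 (0.04 log units; within the scatter), the expectation is that the new step in this assay will be of similar size, a step that the limit leaves unreadable from compound 3 to compound 4, starting from the limit shown for compound 3. Compound 4 is therefore estimated at 60000 nM, with a range from 30000 nM to 150000 nM, and it is likely that only a limit will be reported again.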

Compound 4, half-maximal inhibitory concentration: > 50000 nM
Compound 4: a limit, no number; the forecaster's own chance of this, stated with the estimate: 75%; the middle value does not contradict the limit.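

In this assay compound 4, like compound 3, gives only a limit and no number, so no step can be read between the two compounds: the limit of > 50000 nM in this assay, at which 2 of the 4 values shown sit.

What the compounds shown leave open is whether chloro in place of methyl on an aromatic carbon changes the antiproliferative activity at all on the core of compound 3, where neither compound has a measured number.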